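A few compounds are considered here, and "the series" means these few. Any claim that something is new, unique, unknown or untested is made for them only; others in the source may bear on it.

Working notes on the series. Compound 1 `Cc1cc(NC(=O)Nc2ccccc2C(F)(F)F)c2ccccc2n1` is the reference point. In an ADME assay on HepG2 cells (Homo sapiens) for cytotoxicity, with a stated time of 72 h (on this read-out lower numbers stand for an effect already at smaller amounts and higher numbers for an effect only at larger amounts of compound), compound 1 gives > 25000 nM, a limit of the assay rather than a number. Compound 2 `Cc1cc(NC(=O)Nc2cccc(C(N)=O)c2)c2ccccc2n1` gives > 25000 nM in this assay, again a limit. Compound 3 `Cc1cc(NC(=O)Nc2ccc3[nH]cnc3c2)c2ccccc2n1` gives > 25000 nM in this assay, also a limit. Compound 1 thus stands where every measured value stands, at the limit of > 25000 nM in this assay, at which 3 of the 3 values shown sit. For the measured compounds named here, no two measured compounds differ in a single place, so no measured step exists. Compound 4 `Cc1cc(NC(=O)Nc2ccccc2OC(F)(F)F)c2ccccc2n1` differs from compound 1 by trifluoromethoxy in place of trifluoromethyl on an aromatic carbon. Because compound 1 sits at the limit of > 25000 nM in this assay, at which 3 of the 3 values shown sit, no step beyond the scatter is expected in this assay, and a limit is again the likely read-out. For compound 4 the estimated value is 30000 nM, range 15000 nM to 60000 nM, an expected step that the limit leaves unreadable from compound 1 to compound 4.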

Compound 4, half-maximal effective concentration: > 25000 nM
Compound 4 was reported as a limit; the forecaster's own chance of this, stated with the estimate: 85%; the middle value does not contradict the limit.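

No step can be read between compound 1 and compound 4 in this assay, as both stand at a limit: the limit of > 25000 nM in this assay, at which 4 of the 4 values shown sit. For none of the compounds shown does this assay give a number, so the concentration at which any of them would take effect stays open.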